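Flipping the Double Bond Geometry of a Glycosylated Oxindole

The source may hold more compounds than are shown below. What is called first, only, known or untested is meant among the compounds shown, and "the series" means these compounds.

Three glycosylated triazole compounds have been tested in a functional assay on DU-145 cells (Homo sapiens) for cytotoxicity, read by sulforhodamine B assay, with a stated time of 48 h; on this read-out lower numbers stand for stronger inhibition and higher numbers for weaker inhibition. Compound 1 `CC(=O)OC[C@H]1O[C@@H](n2cc(Cn3cc(/C=C4/C(=O)Nc5ccccc54)c4ccccc43)nn2)[C@H](OC(C)=O)[C@@H](OC(C)=O)[C@@H]1OC(C)=O` gives only a limit in this assay, > 200000 nM. Compound 2 `COc1ccc2c(c1)c(/C=C1/C(=O)Nc3ccc(F)cc31)cn2Cc1cn([C@@H]2O[C@H](COC(C)=O)[C@@H](OC(C)=O)[C@H](OC(C)=O)[C@H]2OC(C)=O)nn1` likewise gives a limit, > 200000 nM. Going by the values given here, compound 3 `CC(=O)OC[C@H]1O[C@@H](n2cc(CN3C(=O)/C(=C\c4ccccc4)c4ccccc43)nn2)[C@H](OC(C)=O)[C@@H](OC(C)=O)[C@@H]1OC(C)=O` is the only one with a number, giving 24100 nM in this assay, while the limit of > 200000 nM in this assay, at which 2 of the 3 values shown sit, marks where the other two sit. Compound 4 `CC(=O)OC[C@H]1O[C@@H](n2cc(CN3C(=O)/C(=C/c4ccccc4)c4ccccc43)nn2)[C@H](OC(C)=O)[C@@H](OC(C)=O)[C@@H]1OC(C)=O` has not been measured yet. It differs from compound 3 in a single respect: the two compounds have the same atoms and bonds and differ only in configuration as drawn: 1 of 6 stereo elements differ; a double bond is drawn Z in compound 3 and E in compound 4. Among the compounds with values here, no comparison between measured compounds addresses such a change, so the expectation rests on compound 3 alone. The expected step, a 1.2-fold higher number from compound 3 to compound 4 (0.10 log units; within the scatter), is small and in no clear direction beyond the scatter. Compound 4 is therefore estimated at 30000 nM, within 8000 nM to 110000 nM.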

Compound 4, half-maximal inhibitory concentration: 22800 nM
Beside the measured number, compound 4's estimate is 1.3-fold (0.12 log units) above it; low and high end bracket the measured number.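

In this assay, changing the double bond from Z to E comes with a 1.1-fold lower number from compound 3 to compound 4 (0.02 log units; within the scatter), so the geometry at this position makes no difference that can be told from the scatter. The earlier compounds shown here offered no comparison of this kind. This step can be read as belonging to the double bond alone, because nothing else changes: the fact that compounds 3 and 4 differ only in the configuration as drawn

The compounds shown leave open whether the geometry would matter as little with free hydroxyl groups in place of the acetate groups. They also leave open whether it would matter as little with an amine on the shared core.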